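This account rests on a few compounds, and the source may have more. Where it says the series, first, only, none or still open, it means among the compounds named here.

In a functional assay on HFF cells (Homo sapiens) for cytotoxicity (a higher number here means a weaker inhibitor, a lower number a stronger inhibitor), three compounds have been measured, and none yields a number. Compound 1 `Cc1cccc(/C=C2\SC(=S)N(NS(=O)(=O)c3ccccc3)C2=O)c1` gives > 100000 nM as a limit. Compound 2 `O=C1/C(=C/c2ccc(Cl)c(Cl)c2)SC(=S)N1NS(=O)(=O)c1cccs1` gives > 100000 nM as a limit. Compound 3 `O=C1/C(=C/c2ccc(Cl)c(Cl)c2)SC(=S)N1NS(=O)(=O)c1ccccc1` gives > 100000 nM as a limit, so its standing is that of the whole set. The evidence is the limit of > 100000 nM in this assay, at which 3 of the 3 values shown sit, and nothing finer.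

Compound 4 `O=C1/C(=C/c2cc(F)c(F)cc2F)SC(=S)N1NS(=O)(=O)c1ccccc1` keeps the phenyl on the sulfonyl sulfur of compound 3 and alters one place only: 2,4,5-trifluorophenyl in place of 3,4-dichlorophenyl on a double-bonded chain carbon bound to a double-bonded ring carbon is the whole change. The closest guide is a step that the two limits leave unreadable from compound 1 to compound 3 at the same place. The other is a step that the two limits leave unreadable from compound 2 to compound 3 at the sulfonyl sulfur. Neither has a readable size, so neither offers a measured shift to carry over.

In this assay no step beyond the scatter is expected, and compound 4 is expected to sit at the same limit. The expected step is a number no higher from compound 3 to compound 4 (the limit leaves the size open) on this reading. For compound 4 the estimate is 100000 nM with an expected range from 50000 nM to 200000 nM in this series.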

Compound 4, half-maximal inhibitory concentration: > 100000 nM
Compound 4 was reported as a limit (the forecaster's own chance of this, stated with the estimate: 85%); the middle value lies on the limit itself.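

In this assay compound 4 gives > 100000 nM, which is a limit. The steps to compound 4 from compound 3 and from compound 1 therefore cannot be read. The compounds shown leave open whether a change at either place shifts the value at all: the limit of > 100000 nM in this assay, at which 4 of the 4 values shown sit.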